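Phenol methylation in two hydrazone series

The source may hold more compounds than are shown below. What is called first, only, known or untested is meant among the compounds shown, and "the series" means these compounds.

Compound 1 `COc1cc(/C=N/NC(=O)OCc2ccccc2)cc(OC)c1O` and compound 2 `COc1cc(/C=N/NC(=O)OCc2ccccc2)cc(OC)c1OC` share a core and differ by methyl in place of hydrogen on an oxygen on an aromatic ring. In a physicochemical assay on cells (Homo sapiens), with a stated time of 18 h, tested at 10 uM (a lower number here means a stronger effect, a higher number a weaker effect of the compound at the concentration tested), compound 1 gives 3%, and compound 2 gives 100%; the step is a number 97 percentage points higher from compound 1 to compound 2 (beyond the scatter). Compound 3 `Oc1ccc(/C=N/Nc2nc3ccccc3s2)cc1O` sits on a different core; the difference between the two cores is not broken down here. In this assay compound 3 gives 7%. Compound 4 `COc1cc(/C=N/Nc2nc3ccccc3s2)ccc1O` differs from compound 3 by methyl in place of hydrogen on an oxygen on an aromatic ring, the same change at the same kind of place as from compound 1 to compound 2. The step from compound 3 to compound 4 is expected to be a number 43 percentage points higher from compound 3 to compound 4 (beyond the scatter), smaller than the earlier one, because a number 97 percentage points higher from compound 1 to compound 2 (beyond the scatter) removed the last hydroxy, whereas compound 4 retains one. For compound 4 the estimate in this assay is 50%, between 15% and 95%.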

Compound 4, a percentage reported as activity, at one concentration (the size of the read-out at that concentration, not a potency): 7%
For compound 4 the middle estimate is 43 percentage points above the measured one, and the stated range ends above it.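

In this assay methyl in place of hydrogen on an oxygen on an aromatic ring gives no change at the digits printed from compound 3 to compound 4 (within the scatter), against a number 97 percentage points higher from compound 1 to compound 2 (beyond the scatter) on the core of compound 1. The size of the step therefore does not carry from one core to the other in this pair, but the two pairs differ both in core and in whether a hydroxy remains on the ring, and they cannot separate these two differences. Nothing at hand bears on why the two steps differ.

Open, going by these compounds, is whether methyl on the remaining hydroxy of compound 4 would give a large step on this core. Also open, on these data alone, is how an amine or a carboxylic acid in place of that hydroxy would read.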